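A few compounds are considered here, and "the series" means these few. Any claim that something is new, unique, unknown or untested is made for them only; others in the source may bear on it.

In a functional assay on the whole organism for agonist activity, with Mus musculus as the target (on this read-out higher numbers stand for an effect only at larger amounts of compound and lower numbers for an effect already at smaller amounts), compound 1 `O=C1NCCN1CC#CCn1ccnc1` gives > 100 mg/kg, which is a limit and not a number. Compound 2 `Cc1cncn1CC#CCN1CCNC1=O` gives > 100 mg/kg, also a limit. Going by the values given here, the only measured change, methyl in place of hydrogen on an aromatic carbon, is a step that the two limits leave unreadable from compound 1 to compound 2, so it sets no size for the next step. Compound 3 `CN(C)CC#CCN1CCNC1=O` carries dimethylamino in place of 1H-imidazol-1-yl on a saturated chain carbon bound to a triple-bonded carbon. A move towards smaller doses is expected, since compound 3 lacks the aromatic ring while compound 1 and compound 2 share it and sit at the limit of > 100 mg/kg in this assay, at which 2 of the 2 values shown sit. The expected step is an at least 3.3-fold lower number from compound 1 to compound 3 (0.52 log units; beyond the scatter). Compound 3 is estimated at 30 mg/kg, with an expected range of 3 mg/kg to 200 mg/kg.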

Compound 3, dose for half-maximal effect: 9.7 mg/kg
Beside the measured number, compound 3's estimate is 3.1-fold (0.49 log units) above it; the measured number falls inside the stated range.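

In this assay, the change at this position, dimethylamino in place of 1H-imidazol-1-yl on a saturated chain carbon bound to a triple-bonded carbon, gives an at least 10-fold lower number from compound 1 to compound 3 (1.01 log units; beyond the scatter). Going by these compounds alone, this is the first readable step, as the methyl step on the aromatic carbon cannot be read. Compound 3 is the only compound shown that leaves the limit: the limit of > 100 mg/kg in this assay, at which 2 of the 3 values shown sit.

The step has only a lower bound, since the value of compound 1 is a limit. Going by these compounds, whether other amines in the same place, such as diethylamino or pyrrolidin-1-yl, keep or lower the dose remains open.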